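Carbamate for benzyl on the aromatic oxygen of compound 1

This account rests on a few compounds, and the source may have more. Where it says the series, first, only, none or still open, it means among the compounds named here.

Among the compounds with values here, compound 1 `CC(C)=CCC1Cc2c(OCc3ccccc3)cc(=O)n(CCCO)c2CC1(C)C` gives -0.3% in a functional assay on PANC-1 cells (Homo sapiens) for inhibition, read by MTT assay, with a stated time of 24 h, tested at 10 uM (on this read-out higher numbers stand for more inhibition at the one concentration tested (going by the name of the read-out) and lower numbers for less inhibition), the lowest of the three numbers known. Compound 2 `CC(C)=CCC1Cc2c(OCCCNS(=O)(=O)c3ccc(Br)cc3)cc(=O)n(CCCO)c2CC1(C)C` gives 19.5% and compound 3 `COc1ccc(C(=O)NCCCOc2cc(=O)n(CCCO)c3c2CC(CC=C(C)C)C(C)(C)C3)cc1` gives 55.5%; both carry, on the same aromatic oxygen that bears the benzyl group in compound 1, a chain ending in an aryl-substituted amine. Within the data shown here, the one step between compounds that differ in a single place is a number 36 percentage points higher from compound 2 to compound 3 (beyond the scatter), where a (4-methoxyphenyl)carbonyl replaces a (4-bromophenyl)sulfonyl on that amine nitrogen.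

Compound 4 `COc1ccccc1NC(=O)Oc1cc(=O)n(CCCO)c2c1CC(CC=C(C)C)C(C)(C)C2` differs from compound 1 as follows: (2-methoxyphenyl)carbamoyl in place of benzyl on an oxygen on an aromatic ring. Among the measured compounds shown here, no measured step changes this oxygen directly, so compound 4 is judged from what compounds 1, 2 and 3 show: every compound with an aryl group joined through a nitrogen-containing linker on that oxygen gave more inhibition than compound 1, and the carbonyl-linked aryl of compound 3 gave the highest value. Compound 4 carries a carbamoyl group, which also puts a carbonyl and an amine nitrogen next to the aryl ring. A rise beyond the scatter is therefore expected, though smaller than that of compound 3, because the closest comparison compound 2 gives 19.5%, only moderately above compound 1, while compound 4 lacks the three-carbon chain of compound 3. The expected step is a number 25.3 percentage points higher from compound 1 to compound 4 (beyond the scatter). Compound 4 is estimated at 25%, within 0% to 55%.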

Compound 4, a percentage reported as inhibition, at one concentration (the size of the read-out at that concentration, not a potency): 71.1%
Compound 4: middle estimate off by 46.1 percentage points, on the low side; measured number above the stated range.
By their numbers in this assay, from the lowest: compound 1; then compound 2; then compound 3; then compound 4.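

In this assay, within the data shown here, the step of a number 71.4 percentage points higher from compound 1 to compound 4 (beyond the scatter) is the first single-place change on the oxygen on the aromatic ring, whereas the earlier step changed only the group on a distant amine nitrogen. It shows that the substituent on this oxygen alone can take the core of compound 1 from no measurable inhibition to a clear effect at the one concentration tested, and that compound 4 does so with the (2-methoxyphenyl)carbamoyl group attached directly to this oxygen, with no intervening alkyl chain. The change replaces benzyl with a larger group that brings a nitrogen, a hydrogen-bond donor and hydrogen-bond acceptors, but no measurement given here explains why the number rises.

The step changes the linking atoms and adds the methoxy group together, so the compounds shown leave open how much each contributes; a plain phenylcarbamoyl group on this oxygen, or a methylcarbamoyl group with no aryl ring, would separate these parts. They also leave open whether the effect of compound 4 holds at other concentrations, since a single-concentration percentage gives no potency.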